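The source may report more compounds than this note shows. Statements on the series, on what has been measured and on what is new or still open speak of the compounds shown alone.

Values in an ADME assay on MT4 cells (Homo sapiens) for cytotoxicity, read by MTT assay, with a stated time of 4 days (on this read-out higher numbers stand for lower toxicity in this test and lower numbers for higher toxicity in this test), so far:

Compound 1 `Cc1ccc(-c2c(C)c(-c3ccc(C)c(C)c3)c(C(OC(C)(C)C)C(=O)O)c(C)c2NS(C)(=O)=O)cc1C` gives 15000 nM
Compound 2 `Cc1ccc(-c2c(C)c(-c3ccc(Cl)cc3)c(C(OC(C)(C)C)C(=O)O)c(C)c2NS(C)(=O)=O)cc1C` gives 26000 nM

Among the measured compounds shown here, these are the only two measured compounds, and their numbers lie within the scatter of each other, so compound 1 holds no distinct place on this scale. For the measured compounds named here, the one measured step, a 1.7-fold higher number from compound 1 to compound 2 (0.24 log units; within the scatter), puts 4-chlorophenyl in place of 3,4-dimethylphenyl on an aromatic carbon. The open question is compound 3 `Cc1ccc(-c2c(C)c(-c3ccc(C)c(C)c3)c(C(OC(C)(C)C)C(=O)O)c(C)c2N)cc1C`, which differs from compound 1 by hydrogen in place of methylsulfonyl on a nitrogen on an aromatic ring (methanesulfonamido to amino). The measured step concerns another place on the core, so nothing measured speaks directly to this change, and the estimate must stay wide. With compound 1 at 15000 nM as the anchor and no measured step beyond the scatter, no shift beyond the scatter is expected in this assay for this change. The expected step is a 1.1-fold lower number from compound 1 to compound 3 (0.03 log units; within the scatter) and it remains an estimate. For compound 3 the expected value is 14000 nM (estimated range 5000 nM to 40000 nM).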

Compound 3, half-maximal cytotoxic concentration: 12000 nM
Estimate against measurement, compound 3: 1.2-fold (0.07 log units) above; the range from low to high includes it.
By their numbers in this assay, from the lowest: compounds 3, 1 and 2 (each within the scatter of the next, the first and the last beyond it).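

Among the compounds shown here, until now the only measured step concerned a different place on the core, and this is the first reading at the nitrogen on an aromatic ring. In this assay hydrogen in place of methylsulfonyl gives a 1.3-fold lower number from compound 1 to compound 3 (0.10 log units; within the scatter) and so stays within the scatter, which means that, on the core of compound 1, methanesulfonamido to amino takes away a methylsulfonyl of 4 heavy atoms without a distinct shift on this read-out. Nothing at hand explains this result or says what the sulfonyl part contributes at this place.

The compounds shown leave open how other groups on this nitrogen would read in this assay, for example an acetyl group, an ethylsulfonyl group with its longer chain, or two methyl groups giving a tertiary amine. They also leave open whether the same change from methanesulfonamido to amino would stay within the scatter on the core of compound 2, which carries 4-chlorophenyl in place of 3,4-dimethylphenyl.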